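Swapping the amide's aryl group on the weakest triazole analog

A few compounds are considered here, and "the series" means these few. Any claim that something is new, unique, unknown or untested is made for them only; others in the source may bear on it.

Measured compounds: compound 1 `COc1ccc(-n2c(CCc3ccccc3)nnc2[C@H](NC(=O)Cc2ccccn2)c2c[nH]c3ccccc23)c(OC)c1` gives 35 nM in a functional assay on CHO cells for antagonist activity at growth hormone secretagogue receptor type 1 (Homo sapiens); a higher number here means a weaker inhibitor, a lower number a stronger inhibitor; compound 2 `CCc1ccc(Cn2c(CCc3ccccc3)nnc2[C@H](NC(=O)Cc2ccccn2)c2c[nH]c3ccccc23)cc1` gives 124 nM; compound 3 `COc1ccc(Cn2c(CCc3ccccc3)nnc2[C@H](NC(=O)Cc2ccccn2)c2c[nH]c3ccccc23)cc1` gives 6 nM.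

Compound 2 has the highest number of the three and is therefore the weakest inhibitor; the nearest is compound 1, with a 3.5-fold higher number from compound 1 to compound 2 (0.55 log units; beyond the scatter) separating them, and the furthest is compound 3, as a 21-fold lower number from compound 2 to compound 3 (1.32 log units; beyond the scatter) shows. Compound 4 `CCc1ccc(Cn2c(CCc3ccccc3)nnc2[C@H](NC(=O)c2cnccn2)c2c[nH]c3ccccc23)cc1` changes a different part of the molecule: pyrazin-2-yl in place of (pyridin-2-yl)methyl on a carbonyl carbon. For the measured compounds named here, none of the measured steps touches the amide side, so they give no direct guide to its size or direction. The expectation is therefore a step of a 1.0-fold lower number from compound 2 to compound 4 (0.01 log units; within the scatter), within the scatter. Compound 4 is estimated at 120 nM, with a range from 35 nM to 400 nM.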

Compound 4, antagonist equilibrium constant: 76 nM
Estimate against measurement, compound 4: 1.6-fold (0.20 log units) above; low and high end bracket the measured number.
By their numbers in this assay, from the lowest: compound 3; then compound 1; then compounds 4 and 2 (each within the scatter of the next).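

In this assay, for the compounds shown here, the first change on the amide side, pyrazin-2-yl in place of (pyridin-2-yl)methyl on the carbonyl carbon, gives a 1.6-fold lower number from compound 2 to compound 4 (0.21 log units; within the scatter) and so leaves compound 2 and compound 4 indistinguishable. This change adds a ring hetero atom and a hydrogen-bond acceptor, yet its step is far smaller than the one on the aromatic-nitrogen side, a 21-fold lower number from compound 2 to compound 3 (1.32 log units; beyond the scatter). No supporting evidence explains this outcome. Going by these compounds, whether a plain phenyl or a longer chain such as 2-(pyridin-2-yl)ethyl on the carbonyl carbon would behave alike remains open. So does whether pyrazin-2-yl gives the same result alongside the 4-methoxybenzyl group of compound 3.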